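The source may hold more compounds than are shown below. What is called first, only, known or untested is meant among the compounds shown, and "the series" means these compounds.

In a functional assay on T47D cells (Homo sapiens) for inhibition, read by sulforhodamine B assay, with a stated time of 48 h (on this read-out lower numbers stand for stronger inhibition of growth and higher numbers for weaker inhibition of growth), compound 1 (`N#Cc1c(-c2nnc(O)c3nn(-c4ccccc4)cc23)nn(-c2ccccc2)c1-c1ccccc1`) gives 2950 nM, while compound 3 (`N#Cc1c(-c2nnc(-c3ccccc3)c3nn(-c4ccccc4)cc23)nn(-c2ccccc2)c1-c1ccccc1`) gives 21800 nM, the higher of the two measured numbers. Compound 2 (`N#Cc1c(-c2nnc(O)c3nn(-c4ccc(Cl)cc4)cc23)nn(-c2ccccc2)c1-c1ccccc1`) reads > 100000 nM, which is a limit of the assay and not a number. Compound 4 (`N#Cc1c(-c2nnc(-c3ccccc3)c3nn(-c4ccc(Cl)cc4)cc23)nn(-c2ccccc2)c1-c1ccccc1`) differs from compound 3 by one change, phenyl to 4-chlorophenyl: chloro in place of hydrogen on an aromatic carbon. The same replacement has been measured only once, as an at least 33-fold higher number from compound 1 to compound 2 (1.53 log units; beyond the scatter), a large step. Exchanging hydroxy for phenyl gave a 7.4-fold higher number from compound 1 to compound 3 (0.87 log units; beyond the scatter), a modest step, so the parent here already starts from a higher number. A higher number is therefore expected in this assay, though one resting on a single precedent. The expected size is a 2.8-fold higher number from compound 3 to compound 4 (0.44 log units; beyond the scatter). Compound 4 is estimated at 60000 nM, with an expected range of 22000 nM to 100000 nM.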

Compound 4, concentration for 50% growth inhibition: 38000 nM
Compound 4: middle estimate off by 1.6-fold (0.20 log units), on the high side, within the range that was stated.
By their numbers in this assay, from the lowest: compound 1; then compounds 3 and 4 (each within the scatter of the next). At a limit, above all of these: compound 2.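

In this assay, chloro in place of hydrogen gives a 1.7-fold higher number from compound 3 to compound 4 (0.24 log units; within the scatter), so the size of this change at this position depends on the core that carries it: the same change on two cores in this assay, an at least 33-fold higher number (1.53 log units; beyond the scatter) from compound 1 to compound 2 and a 1.7-fold higher number (0.24 log units; within the scatter) from compound 3 to compound 4, at least 19-fold (1.28 log units) apart, beyond the scatter of two such steps. Compound 2 reads > 100000 nM, a limit of the assay and not a number. With the chloro present, phenyl in place of hydroxy gives an at least 2.6-fold lower number from compound 2 to compound 4 (0.42 log units; beyond the scatter), the opposite direction to the same change without chloro: the same change on two cores in this assay, a 7.4-fold higher number (0.87 log units; beyond the scatter) from compound 1 to compound 3 and an at least 2.6-fold lower number (0.42 log units; beyond the scatter) from compound 2 to compound 4, at least 19-fold (1.28 log units) apart, beyond the scatter of two such steps.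

As far as these compounds go, what a methoxy group or an amine would do in place of the chloro remains open. The compounds shown also leave open why the two cores respond so differently.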